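This account rests on a few compounds, and the source may have more. Where it says the series, first, only, none or still open, it means among the compounds named here.

Measured compounds:
- compound 1, `Cc1nc(-c2ccc(F)cc2)sc1COc1ccc(CCC(=O)O)cc1`: 251 nM
- compound 2, `Cc1nc(-c2ccccc2)sc1COc1ccc2c(c1)OCC2CC(=O)O`: 102 nM

In an assay on CHO cells for agonist activity at Free fatty acid receptor 1 (Homo sapiens), read by FLIPR (on this read-out lower numbers stand for an effect already at smaller amounts and higher numbers for an effect only at larger amounts of compound), compound 1 gives 251 nM, while compound 2 gives 102 nM. Compound 2 thus holds the lowest of the two numbers, and the gap to compound 1 lies beyond the usual scatter; as the two compounds differ in more than one place, no single change can be read out of that gap.

Compound 3, `Cc1ccc(-c2nc(C)c(COc3ccc4c(c3)OCC4CC(=O)O)s2)cc1`, has not yet been measured in this assay. It is derived from compound 2 by methyl in place of hydrogen on an aromatic carbon. Among the compounds with values here, there is no measured pair in this set that isolates such a change, so the size of the step rests on expectation alone. A step of at most modest size, and more likely downward than upward, is expected from compound 2 to compound 3, a 1.3-fold lower number from compound 2 to compound 3 (0.11 log units; within the scatter). For compound 3 the expected value in this assay is 80 nM, within a range of 30 nM to 250 nM.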

Compound 3, half-maximal effective concentration: 94 nM
Beside the measured number, compound 3's estimate is 1.2-fold (0.07 log units) below it; the measured number falls inside the stated range.
By their numbers in this assay, from the lowest: compounds 3 and 2 (each within the scatter of the next); then compound 1.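

In this assay, within the data shown here, the change from phenyl to 4-methylphenyl gives a 1.1-fold lower number from compound 2 to compound 3 (0.04 log units; within the scatter) and is the first change that can be read on its own. At this place, para to a large group on the six-membered aromatic ring of carbon only, a methyl in place of hydrogen therefore leaves the number within the scatter. No measurement shown here bears on why the number stays there.

Going by these compounds, it remains open whether a larger or different group at this place, such as trifluoromethyl, methoxy or an amine, would also stay within the scatter of compound 2 or move beyond it. On these data alone, it also remains open whether the same methyl would give a step of similar size on the core of compound 1.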